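Fluoro in Place of Methyl: Expecting Compound 4

The source may hold more compounds than are shown below. What is called first, only, known or untested is meant among the compounds shown, and "the series" means these compounds.

Compound 1 `CC/C=C/C(=O)c1ccccc1`: "not active" (no number reported)
Compound 2 `Cc1ccc(C(=O)/C=C/CCc2ccccc2)cc1`: 3020 nM
Compound 3 `O=C(/C=C/CCc1ccccc1)c1cccc(F)c1`: 2370 nM

In a functional assay on HEK293 cells for antagonist activity at G-protein coupled receptor 52 (Homo sapiens), read by cAMP accumulation, with stated times of 15 min and 30 min (a higher number here means a weaker inhibitor, a lower number a stronger inhibitor), compound 2 gives the higher of the two numbers, while compound 3 stands only slightly lower, within the scatter, and compound 1 yields no single number. Compound 4 `O=C(/C=C/CCc1ccccc1)c1ccc(F)cc1` differs from compound 2 by fluoro in place of methyl on an aromatic carbon. For the measured compounds named here, no pair of measured compounds shows this exact change, so the step can only be judged from what is at hand. Compound 3, which also carries a fluoro on its ring and gives 2370 nM, sits within the scatter of compound 2, so the step is expected to be small, a 1.2-fold lower number from compound 2 to compound 4 (0.08 log units; within the scatter), none beyond the scatter. Compound 4 is therefore estimated at 2500 nM, with a range from 1200 nM to 5500 nM.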

Compound 4, half-maximal inhibitory concentration: "not active" (no number reported)
The entry for compound 4 holds no number; the estimate stays without a comparison.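

For the compounds shown here, compound 4 gives "not active" (no number reported) and so no step from compound 2 to compound 4 can be read. No measurement at hand bears on this result. The compounds shown leave open how fluoro in place of methyl alters the response of compound 2.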